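This account rests on a few compounds, and the source may have more. Where it says the series, first, only, none or still open, it means among the compounds named here.

Measured in an ADME assay on HepG2 cells (Homo sapiens) for cytotoxicity, read by CellTiter-Glo and resazurin assay, with a stated time of 72 h; on this read-out lower numbers stand for an effect already at smaller amounts and higher numbers for an effect only at larger amounts of compound:
Compound 1 `CC(C)N(Cc1cccc(OCCCCCC(=O)O)c1)C(=O)c1ccc(-c2cccc(N(C)C)c2)cc1` gives > 26000 nM, a limit of the assay.
Compound 2 `CC(C)N(Cc1cccc(OCCCCCC(=O)O)c1)C(=O)c1ccc(-c2cccc3ccccc23)cc1` gives > 26000 nM, a limit of the assay.
Compound 3 `CC(C)N(Cc1cccc(OCCCCCC(=O)O)c1)C(=O)c1ccc(-c2ccncc2)cc1` gives > 26000 nM, a limit of the assay.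

Compound 2 therefore stands at the limit of this assay, and its value is a limit and not a number. The same holds for the other two compounds, as the limit of > 26000 nM in this assay, at which 3 of the 3 values shown sit, shows. The steps among the measured compounds, a step that the two limits leave unreadable from compound 1 to compound 2, a step that the two limits leave unreadable from compound 1 to compound 3 and a step that the two limits leave unreadable from compound 2 to compound 3, all exchange the aromatic substituent on the shared core, and each of them remains unreadable, since both ends sit at a limit.

Compound 4 `CCOC(=O)CCCCCOc1cccc(CN(C(=O)c2ccc(-c3cccc4ccccc34)cc2)C(C)C)c1` differs from compound 2 by ethyl in place of hydrogen on an oxygen next to a carbonyl group. Within the data shown here, none of the measured steps touches this part of the molecule, so no measured step bears directly on it; the only guidance is that every measured compound, whatever its aromatic substituent, reached the limit. An estimated step of a number no higher from compound 2 to compound 4 (the limit leaves the size open) is therefore expected, with no change beyond the scatter. Compound 4 is expected to give about 26000 nM, with a range from 10000 nM to 60000 nM, most likely again reported only as a limit.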

Compound 4, half-maximal effective concentration: > 26000 nM
Compound 4 was reported as a limit; the forecaster's own chance of this, stated with the estimate: 70%; the middle value lies on the limit itself.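

In this assay compound 4 gives > 26000 nM as a limit of the assay and not a number. Among these compounds, compound 2 also sits at a limit, so no step between compound 2 and compound 4 can be read, and all the values shown share one limit: the limit of > 26000 nM in this assay, at which 4 of the 4 values shown sit.

The compounds shown leave open at what concentration any of them would affect these cells, and whether the ethyl in place of hydrogen changes that concentration.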